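The source may report more compounds than this note shows. Statements on the series, on what has been measured and on what is new or still open speak of the compounds shown alone.

Series so far, in a functional assay on HCT-116 cells (Homo sapiens) for antiproliferative activity, read by MTT assay, with a stated time of 72 h; on this read-out lower numbers stand for stronger inhibition and higher numbers for weaker inhibition:
compound 1 `O=C(CCc1cccc2c1B(O)OC2)Nc1ccccc1`: 350 nM
compound 2 `O=C(CCc1cccc2c1B(O)OC2)Nc1cccc(-c2ccccc2)c1`: 890 nM
compound 3 `O=C(CCc1cccc2c1B(O)OC2)Nc1cccc(-c2cccc(F)c2)c1`: 460 nM

Compound 3 sits second highest of the three numbers, but it cannot be separated from either of the other two: a 1.3-fold higher number from compound 1 to compound 3 (0.12 log units; within the scatter), and a 1.9-fold lower number from compound 2 to compound 3 (0.29 log units; within the scatter). Within the data shown here, only one step lies beyond the scatter, and it is modest: a 2.5-fold higher number from compound 1 to compound 2 (0.41 log units; beyond the scatter).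

Next comes compound 4 `O=C(CCc1cccc2c1B(O)OC2)Nc1cccc(-c2cccc(OC(F)(F)F)c2)c1`, with trifluoromethoxy in place of fluoro on an aromatic carbon. Among the measured compounds shown here, no measured step makes this exchange. The closest evidence is fluoro in place of hydrogen, a 1.9-fold lower number from compound 2 to compound 3 (0.29 log units; within the scatter), which stays within the scatter. The larger phenyl addition gives only the modest 2.5-fold higher number from compound 1 to compound 2 (0.41 log units; beyond the scatter). On this limited evidence, no step beyond the scatter is expected in this assay, with a slightly higher number as the likelier direction. The expected step is a 1.2-fold higher number from compound 3 to compound 4 (0.08 log units; within the scatter).

For compound 4 the estimate is 550 nM, with an expected range of 220 nM to 1400 nM.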

Compound 4, half-maximal inhibitory concentration: 310 nM
The estimate for compound 4 lay 1.8-fold (0.25 log units) above the measured number; measured number inside the range.
By their numbers in this assay, from the lowest: compounds 4, 1, 3 and 2 (each within the scatter of the next, the first and the last beyond it).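

This aromatic carbon, meta to a large group, takes trifluoromethoxy (5 heavy atoms) in place of fluoro (1 heavy atom) without a change that can be told from the scatter in this assay, a 1.5-fold lower number from compound 3 to compound 4 (0.17 log units; within the scatter). Among these compounds, measured against the bare phenyl group, the same substitution gives the first step beyond the scatter at this position, a 2.9-fold lower number from compound 2 to compound 4 (0.46 log units; beyond the scatter), which fluoro alone did not provide; compounds 2 and 4 thus show that a group here can separate a compound from compound 2, though the step is modest. Nothing available explains this step.

Going by these compounds, whether the step follows from the trifluoromethoxy group itself or would also appear with methoxy, an amine or a carboxylic acid at this carbon remains open. Also open, on these data alone, is whether trifluoromethoxy on another carbon of that ring would give a similar number.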